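From a benzoyl to a carbamoyl group

The source may hold more compounds than are shown below. What is called first, only, known or untested is meant among the compounds shown, and "the series" means these compounds.

Measured so far in a functional assay on SEM cells (Homo sapiens) for cytotoxicity, with a stated time of 72 h (a lower number here means that less compound is needed, a higher number that more compound is needed for the effect), for three compounds:
- Compound 1 `C=C[C@@](C)(/C=C/c1ccc(OS(=O)(=O)c2ccc(C)cc2)cc1)CCC=C(C)C` gives > 43400 nM as a limit
- Compound 2 `C=C[C@@](C)(/C=C/c1ccc(O)cc1)CC/C=C/C(=O)c1ccccc1` gives > 36600 nM as a limit
- Compound 3 `C=C[C@@](C)(/C=C/c1ccc(O)c(/C=C/C(=O)c2ccccc2)c1)CCC=C(C)C` gives 8000 nM as a number

Compound 3 is the only one of the three with a true number, since compound 1 and compound 2 reached only limits. Compound 4 `C=C[C@@](C)(/C=C/c1ccc(O)c(/C=C/C(N)=O)c1)CCC=C(C)C` has amino in place of phenyl on a carbonyl carbon and is otherwise the same. For the measured compounds named here, no measured pair shows this change, so the expectation starts from compound 3 at 8000 nM and points to a higher number in this assay beyond the scatter. The estimated step runs a 3.1-fold higher number from compound 3 to compound 4 (0.49 log units; beyond the scatter) on this reasoning. The estimate for compound 4 is 25000 nM within an expected range from 9000 nM to 60000 nM once measured.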

Compound 4, half-maximal effective concentration: > 36600 nM
Compound 4: no number, only a limit; the forecaster's own chance of this, stated with the estimate: 45%; middle value at least 1.4-fold (0.16 log units) from the limit.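

In this assay, putting amino in place of phenyl on this carbonyl carbon means more compound is needed, with an at least 4.5-fold higher number from compound 3 to compound 4 (0.66 log units; beyond the scatter). This is the first single change shown at this position, and the phenyl proves to matter here, since amino does not keep the measured value. Compound 4 reached only a limit, so the full size of the step cannot be read: the limit of > 36600 nM in this assay, at which 2 of the 4 values shown sit.

As far as these compounds go, it remains open whether a smaller carbon group such as methyl would serve as well as phenyl on this carbonyl carbon. A methylamino group, or a phenyl carrying a methoxy group, is equally untested in the compounds shown.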